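Extending the ethyl group on the aryl substituent

This account rests on a few compounds, and the source may have more. Where it says the series, first, only, none or still open, it means among the compounds named here.

Three compounds share one core and differ only in the aryl group carried on it. Compound 1 `CC(=O)Nc1cccc(C2CCN(CCCn3c(-c4ccccc4Cl)nc4ccccc43)CC2)c1` gives 10 nM in an assay for displacement of a labelled ligand from melanin-concentrating hormone receptor 1 (Homo sapiens), read by fluorescence; a lower number here means a stronger inhibitor, a higher number a weaker inhibitor. Compound 2 `CC(=O)Nc1cccc(C2CCN(CCCn3c(-c4ccc(F)cc4)nc4ccccc43)CC2)c1` gives 56 nM in this assay, and compound 3 `CCc1ccc(-c2nc3ccccc3n2CCCN2CCC(c3cccc(NC(C)=O)c3)CC2)cc1` gives 32 nM in this assay. Compound 3 thus holds the second highest of the three numbers: the step of a 3.2-fold higher number from compound 1 to compound 3 (0.51 log units; beyond the scatter) lies beyond the scatter, whereas a 1.8-fold lower number from compound 2 to compound 3 (0.24 log units; within the scatter) does not. Compound 4 `CC(=O)Nc1cccc(C2CCN(CCCn3c(-c4ccc(C(C)C)cc4)nc4ccccc43)CC2)c1` has not been measured. It differs from compound 3 by methyl in place of hydrogen on a saturated chain carbon bound to an aromatic carbon and a saturated chain carbon, so the 4-ethylphenyl becomes a 4-isopropylphenyl. Among the compounds with values here, no measured step adds a methyl to a chain; the nearest is a 1.8-fold lower number from compound 2 to compound 3 (0.24 log units; within the scatter), which enlarges the group on the same aromatic carbon without moving beyond the scatter, while a 5.6-fold higher number from compound 1 to compound 2 (0.75 log units; beyond the scatter) and a 3.2-fold higher number from compound 1 to compound 3 (0.51 log units; beyond the scatter) change the aryl group more broadly. For compound 4 a step of about a 1.1-fold higher number from compound 3 to compound 4 (0.04 log units; within the scatter) in this assay is therefore expected, which stays within the scatter. Compound 4 is estimated at 35 nM in this assay, with a range from 12 nM to 100 nM.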

Compound 4, half-maximal inhibitory concentration: 60 nM
Beside the measured number, compound 4's estimate is 1.7-fold (0.23 log units) below it, and the stated range covers the measured number.
By their numbers in this assay, from the lowest: compound 1; then compounds 3, 2 and 4 (each within the scatter of the next).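

In this assay, the methyl on the saturated chain carbon that turns the 4-ethylphenyl into a 4-isopropylphenyl gives a 1.9-fold higher number from compound 3 to compound 4 (0.27 log units; within the scatter), so this branching does not move the number beyond the scatter. Replacing fluoro with isopropyl on the aromatic carbon gives a 1.1-fold higher number from compound 2 to compound 4 (0.03 log units; within the scatter), which leaves fluoro, ethyl and isopropyl at this position unseparated in this small set. The 2-chlorophenyl group stays apart from the 4-isopropylphenyl as well, with a 6.0-fold higher number from compound 1 to compound 4 (0.78 log units; beyond the scatter), as it did from the other two aryl groups.

Nothing available explains these numbers. Going by these compounds, it remains open whether a tert-butyl, an amine or a carboxylic acid on the same aromatic carbon would separate from this group, and whether a 4-chlorophenyl would match compound 1 or the others.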